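Cytotoxicity of a sulfamoylphenyl amide against three measured analogues

The source may report more compounds than this note shows. Statements on the series, on what has been measured and on what is new or still open speak of the compounds shown alone.

Measured compounds:
- compound 1, `Cc1cc(C)cc(S(=O)(=O)n2c(SCC(=O)Nc3ccccc3C)nc3ccccc32)c1`: 6150 nM
- compound 2, `Cc1cc(C)cc(S(=O)(=O)n2c(SCC(=O)Nc3ccccc3S(C)(=O)=O)nc3ccccc32)c1`: 9310 nM
- compound 3, `Cc1cc(C)cc(S(=O)(=O)n2c(SCC(=O)Nc3ccc(S(C)(=O)=O)cc3)nc3ccccc32)c1`: 10600 nM

These values come from an ADME assay on MT4 cells (Homo sapiens) for cytotoxicity, read by MTT assay, with a stated time of 5 days; on this read-out higher numbers stand for lower toxicity in this test and lower numbers for higher toxicity in this test. Compound 1 gives the lowest number of the three, but its gaps to compound 2 a 1.5-fold higher number from compound 1 to compound 2 (0.18 log units; within the scatter) and to compound 3 a 1.7-fold higher number from compound 1 to compound 3 (0.24 log units; within the scatter) both lie within the scatter, so the three cannot be ranked.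

Compound 4, `Cc1cc(C)cc(S(=O)(=O)n2c(SCC(=O)Nc3ccc(S(N)(=O)=O)cc3)nc3ccccc32)c1`, is not yet measured. It differs from compound 1 in one place: 4-sulfamoylphenyl in place of 2-methylphenyl on an amide-type nitrogen.

The closest measured step is from compound 1 to compound 3, where a 4-(methylsulfonyl)phenyl replaced the same 2-methylphenyl on the amide-type nitrogen and gave a 1.7-fold higher number from compound 1 to compound 3 (0.24 log units; within the scatter). The step of a 1.5-fold higher number from compound 1 to compound 2 (0.18 log units; within the scatter) likewise stayed within the scatter, and a 1.1-fold higher number from compound 2 to compound 3 (0.06 log units; within the scatter) shows that moving the group around the ring changed little. Among the measured compounds shown here, no step here moved beyond the scatter, so for compound 4 a step of about a 1.5-fold higher number from compound 1 to compound 4 (0.19 log units; within the scatter) is expected in this assay, not beyond the scatter. Compound 4 is therefore estimated at 9500 nM, with a range from 4500 nM to 20000 nM.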

Compound 4, half-maximal cytotoxic concentration: 30900 nM
Estimate against measurement, compound 4: 3.3-fold (0.51 log units) below, and the stated range ends below it.
By their numbers in this assay, from the lowest: compounds 1, 2 and 3 (each within the scatter of the next); then compound 4.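

Among the compounds shown here, changing only the methyl on the sulfonyl sulfur to an amino group (a 2.9-fold higher number from compound 3 to compound 4 (0.46 log units; beyond the scatter)) is the one small edit here that moves the number in this assay beyond the scatter, so the group at the end of this aryl ring matters more than the earlier compounds suggested. The larger replacements tell the same story (a 5.0-fold higher number from compound 1 to compound 4 (0.70 log units; beyond the scatter)) and (a 3.3-fold higher number from compound 2 to compound 4 (0.52 log units; beyond the scatter)), whereas the methylsulfonyl analogues had stayed within the scatter of the 2-methylphenyl compound, so the higher number goes with the sulfamoyl group and not with sulfonyl substitution in general. No measurement here explains this shift.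

As far as these compounds go, it remains open whether the amino group's hydrogens matter, which a methylamino or dimethylamino group on the sulfonyl sulfur could test. A carboxylic acid in place of the sulfamoyl group would show how specific the change is.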